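The compounds below may be only part of what the source reports. "The series", "measured", "known", "first", "only" and "open" are said of these compounds alone.

Compound 1 (`CCCCCCCCCCCCCCNC(=O)[C@@H]1CSC(c2ccc(OC)c(OC)c2)N1`) gives 800 nM in a functional assay on WM164 cells (Homo sapiens) for antiproliferative activity, read by sulforhodamine B assay, with a stated time of 48 h; on this read-out higher numbers stand for weaker inhibition and lower numbers for stronger inhibition
Compound 2 (`CCCCCCCCCCCCNC(=O)[C@@H]1CSC(c2ccc(NC(C)=O)cc2)N1`) gives 1200 nM in this assay
Compound 3 (`CCCCCCCCCCCCCCNC(=O)[C@@H]1CSC(c2ccc(NC(C)=O)cc2)N1`) gives 600 nM in this assay

Compound 3 cannot be separated from the other two compounds on these numbers, since both steps that reach it, a 1.3-fold lower number from compound 1 to compound 3 (0.12 log units; within the scatter) and a 2.0-fold lower number from compound 2 to compound 3 (0.30 log units; within the scatter), stay within the scatter. Compound 4 (`CCCCCCCCCCCCCCCNC(=O)[C@@H]1CSC(c2ccc(NC(C)=O)cc2)N1`) departs from compound 3 only in the chain (methyl in place of hydrogen on a saturated chain carbon, ten or more bonds along the chain from an amide-type nitrogen), with methyl in place of hydrogen on a saturated chain carbon, ten or more bonds along the chain from an amide-type nitrogen.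

For the measured compounds named here, only one measured step is of this kind: ethyl in place of hydrogen at the same sort of place, a 2.0-fold lower number from compound 2 to compound 3 (0.30 log units; within the scatter), which is within the scatter. The other step, a 1.3-fold lower number from compound 1 to compound 3 (0.12 log units; within the scatter), swaps the aromatic group on a saturated ring carbon and says nothing about the chain. Going by these compounds, with a single comparable step that never left the scatter, no change beyond the scatter is expected in this assay for this smaller addition, and the direction stays open. The expected step is a 1.1-fold lower number from compound 3 to compound 4 (0.04 log units; within the scatter) and is an estimate only. Compound 4 is estimated at 550 nM in this read-out, with an expected range from 250 nM to 1200 nM for repeated measurements.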

Compound 4, half-maximal inhibitory concentration: 1000 nM
For compound 4 the middle estimate is 1.8-fold (0.26 log units) below the measured one; the measured number falls inside the stated range.
By their numbers in this assay, from the lowest: compounds 3, 1, 4 and 2 (each within the scatter of the next).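

In this assay, methyl in place of hydrogen on a saturated chain carbon, ten or more bonds along the chain from an amide-type nitrogen, gives (a 1.7-fold higher number from compound 3 to compound 4 (0.22 log units; within the scatter)), so this addition joins the ethyl step in staying within the scatter. The propyl addition at the same sort of place gives (a 1.2-fold lower number from compound 2 to compound 4 (0.08 log units; within the scatter)), which is also within the scatter, so compound 2, compound 3 and compound 4, which all carry the 4-acetamidophenyl group, cannot be separated on these numbers, and the chain steps show no trend with chain length. No measurement is available that bears on these numbers or offers an account of them.

The compounds shown leave open whether a much longer chain or a butyl-shortened one would move the number beyond the scatter, and whether an amine or a carboxylic acid at the chain end would do so. They also leave open the aromatic group, since only 3,4-dimethoxyphenyl and 4-acetamidophenyl appear, and a group such as pyridyl or 4-hydroxyphenyl on the same ring carbon has no number here.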